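A few compounds are considered here, and "the series" means these few. Any claim that something is new, unique, unknown or untested is made for them only; others in the source may bear on it.

Compound 1 `N#CC1=C(N)N(c2ccc(S(N)(=O)=O)cc2)C2=C(C(=O)CCC2)C1/C=C/c1ccccc1` — in a functional assay on Ehrlich cells (Mus musculus) for antiproliferative activity, read by trypan blue exclusion, with a stated time of 2 h, tested at 10 ug/mL (a lower number here means a weaker effect, a higher number a stronger effect of the compound at the concentration tested), compound 1 gives 2%.
Compound 2 `COc1ccccc1C1C(C#N)=C(N)N(c2ccc(S(N)(=O)=O)cc2)C2=C1C(=O)CCC2` — in this assay compound 2 gives 0%.
Compound 3 `COc1ccc(C2C(C#N)=C(N)N(c3ccc(S(N)(=O)=O)cc3)C3=C2C(=O)CCC3)cc1` — in this assay compound 3 gives 30%.

Compound 3 stands highest of the three in this assay; compound 1 is its nearest neighbour and compound 2 its furthest, both beyond the scatter. Compound 4 `N#CC1=C(N)N(c2ccc(S(N)(=O)=O)cc2)C2=C(C(=O)CCC2)C1c1cccc([N+](=O)[O-])c1` has not yet been measured. It differs from compound 3 in one place: 3-nitrophenyl in place of 4-methoxyphenyl on a saturated ring carbon. For the measured compounds named here, no measured step involves a nitro group, so none bears directly on this change. The closest steps swap the group on the same saturated ring carbon: a number 28 percentage points higher from compound 1 to compound 3 (beyond the scatter) and a number 30 percentage points higher from compound 2 to compound 3 (beyond the scatter), whereas a number 2 percentage points lower from compound 1 to compound 2 (within the scatter). They show that the group on this carbon can shift the read-out by a modest amount, and that the 2-methoxyphenyl and 4-methoxyphenyl groups gave numbers far apart. With a nitro group untested, the direction is uncertain. A modest fall is expected, a number 18 percentage points lower from compound 3 to compound 4 (beyond the scatter). Compound 4 is therefore estimated at 12%, with a range from 0% to 35%.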

Compound 4, a percentage reported as activity, at one concentration (the size of the read-out at that concentration, not a potency): 42%
Estimate against measurement, compound 4: 30 percentage points below; the measured number lies above the stated range.
By their numbers in this assay, from the lowest: compounds 2 and 1 (each within the scatter of the next); then compound 3; then compound 4.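

In this assay the 3-nitrophenyl group gives the highest number of the four compounds, with a number 12 percentage points higher from compound 3 to compound 4 (beyond the scatter) and with larger gains in a number 40 percentage points higher from compound 1 to compound 4 (beyond the scatter) and in a number 42 percentage points higher from compound 2 to compound 4 (beyond the scatter) on this same saturated ring carbon. The earlier compounds shown here reached their highest number with the 4-methoxyphenyl group, and this result shows that a methoxy group is not needed for a read-out at this level. Nothing measured here explains why the 3-nitrophenyl group gives the higher number.

Because both the substituent and its place on the phenyl ring change from compound 3 to compound 4, the effects of these two changes cannot be separated. From the compounds shown here alone, it also remains open how a plain phenyl group, or a phenyl ring carrying an amine or a carboxylic acid, would read out on this carbon.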